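A few compounds are considered here, and "the series" means these few. Any claim that something is new, unique, unknown or untested is made for them only; others in the source may bear on it.

In a functional assay on HepG2 cells (Homo sapiens) for inhibition, read by MTT assay, with a stated time of 72 h (a higher number here means a weaker inhibitor, a lower number a stronger inhibitor), compound 1 (`CC(C)(C)n1cc2c(n1)C(=O)CC1(CCN(C(=O)c3cc(-c4ccc(Br)cc4)nc4ccccc34)CC1)O2`) gives 820 nM and compound 2 (`CC(C)(C)n1cc2c(n1)C(=O)CC1(CCN(C(=O)c3cc(-c4ccc(N)cc4)nc4ccccc34)CC1)O2`) gives 630 nM, while compound 3 (`CN(C)c1ccc(-c2cc(C(=O)N3CCC4(CC3)CC(=O)c3nn(C(C)(C)C)cc3O4)c3ccccc3n2)cc1`) gives 1730 nM as the highest of the three numbers. Two measured steps lead to compound 3 and both are modest: a 2.1-fold higher number from compound 1 to compound 3 (0.32 log units; beyond the scatter) and a 2.7-fold higher number from compound 2 to compound 3 (0.44 log units; beyond the scatter) in size. The remaining step, a 1.3-fold lower number from compound 1 to compound 2 (0.11 log units; within the scatter) in size, stays within the scatter.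

Compound 4 (`CC(C)(C)n1cc2c(n1)C(=O)CC1(CCN(C(=O)c3cc(Cl)nc4ccccc34)CC1)O2`) has chloro in place of 4-(dimethylamino)phenyl on an aromatic carbon next to the ring nitrogen (chloro in place of 4-(dimethylamino)phenyl on an aromatic carbon) and so loses that entire group. All three measured steps only exchange the group carried on the phenyl and leave the phenyl itself in place, so they bear on this change only loosely. Within the data shown here, no measured compound lacks the phenyl.

Measured against a 2.7-fold higher number from compound 2 to compound 3 (0.44 log units; beyond the scatter) as the largest step seen, a somewhat larger step in this assay is expected for this bigger change. Among the measured compounds shown here, a move toward a higher number is expected, although no measured compound supports that direction. The estimated step is a 1.7-fold higher number from compound 3 to compound 4 (0.24 log units; within the scatter) and carries wide uncertainty. For compound 4 the expected value is 3000 nM (estimated range 1000 nM to 10000 nM).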

Compound 4, half-maximal inhibitory concentration: 4720 nM
The estimate for compound 4 lay 1.6-fold (0.20 log units) below the measured number, and the stated range covers the measured number.
By their numbers in this assay, from the lowest: compounds 2 and 1 (each within the scatter of the next); then compound 3; then compound 4.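

In this assay, chloro in place of the whole phenyl-bearing group on the aromatic carbon next to the ring nitrogen raises the number from each of the three earlier compounds: a 2.7-fold higher number from compound 3 to compound 4 (0.44 log units; beyond the scatter), a 5.8-fold higher number from compound 1 to compound 4 (0.76 log units; beyond the scatter) and a 7.5-fold higher number from compound 2 to compound 4 (0.87 log units; beyond the scatter), all beyond the scatter. Compound 4 is the first shown without the phenyl, so the direction of this change at this position is now measured, and the number stands above those of all three phenyl-bearing compounds, although compound 4 still gives a measurable 4720 nM in this assay. The change from compound 3 is the smallest of the three. That comparison starts from the highest of the earlier numbers, while exchanging the group on the phenyl moved the number far less than removing the phenyl from compound 1 or compound 2. The data shown offer no measurement that accounts for the rise.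

Open, on these data alone, is whether an unsubstituted phenyl, a pyridyl ring or a morpholine at this position would stay close to the phenyl-bearing compounds or to compound 4. Also open, as far as these compounds go, is whether a carboxylic acid or a longer chain on the phenyl would move the number beyond the range seen so far.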